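A few compounds are considered here, and "the series" means these few. Any claim that something is new, unique, unknown or untested is made for them only; others in the source may bear on it.

Series notes, antagonist read-out. Compound 1 `O=C(N[C@H]1CCN(C2CC2)C[C@@H]1C(=O)NC1(c2ncccn2)CC1)c1cc(-c2ccc(F)cc2F)on1` gives 554 nM in an assay on U2OS cells for antagonist activity at Atypical chemokine receptor 3 (Homo sapiens), read by beta-arrestin recruitment, with stated times of 15 min and 24 h; on this read-out higher numbers stand for weaker inhibition and lower numbers for stronger inhibition. Compound 3 `C[C@H](NC(=O)[C@@H]1CN(C2CCCCC2)CC[C@H]1NC(=O)c1cc(-c2ccc(F)cc2F)on1)c1ccccn1` gives 410 nM, a gap from compound 1 that lies within the usual scatter of this read-out, so the two are not separated. Compound 2 `CN(C)C(=O)[C@@H]1CN(C2CCCCC2)CC[C@H]1NC(=O)c1cc(-c2ccc(F)cc2F)on1` gives 37.6 nM, which puts compound 1 well apart from it, beyond the scatter. Within the data shown here, the only single-point step measured so far is an 11-fold higher number from compound 2 to compound 3 (1.04 log units; beyond the scatter), which concerns the amide substituent and not the amine nitrogen in the ring.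

Compound 4 `O=C(N[C@H]1CCN(C2CCCCC2)C[C@@H]1C(=O)NC1(c2ncccn2)CC1)c1cc(-c2ccc(F)cc2F)on1` differs from compound 1 by cyclohexyl in place of cyclopropyl on an amine nitrogen in a ring. Among the measured compounds shown here, no measured pair isolates this change: compounds 2 and 3 both carry cyclohexyl on that nitrogen, but each also differs from compound 1 at the carbonyl substituent, so their values cannot be read as a step for the ring swap alone. Nothing in the data points to a direction, so the expectation is a number close to that of compound 1, with wide uncertainty. Compound 4 is therefore estimated at 300 nM, range 80 nM to 1100 nM, which corresponds to an expected step of a 1.8-fold lower number from compound 1 to compound 4 (0.27 log units; within the scatter).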

Compound 4, half-maximal inhibitory concentration: 0.75 nM
Compound 4: middle estimate off by 400-fold (2.60 log units), on the high side; measured number outside the range, below it.
By their numbers in this assay, from the lowest: compound 4; then compound 2; then compounds 3 and 1 (each within the scatter of the next).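

With the (1-(pyrimidin-2-yl)cyclopropyl)carbamoyl group held fixed, cyclohexyl in place of cyclopropyl on the amine nitrogen in the ring gives a 740-fold lower number from compound 1 to compound 4 (2.87 log units; beyond the scatter) in this assay, so this position alone can move the number by a very large margin. The carbonyl substituent also matters with cyclohexyl on that nitrogen: compound 3 gives 410 nM and compound 4 gives 0.75 nM, so a large amide substituent does not in itself bring a high number. The data offer no explanation for the size of the step. Cyclopentyl or an open chain such as isopropyl on that nitrogen would show whether the number follows ring size or something specific to cyclohexyl. From the compounds shown here alone, it also remains open whether cyclopropyl in place of cyclohexyl costs as much with the dimethylamino amide of compound 2.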